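The source may report more compounds than this note shows. Statements on the series, on what has been measured and on what is new or still open speak of the compounds shown alone.

In a functional assay on HeLa cells (Homo sapiens) for antiproliferative activity, read by sulforhodamine B assay, with a stated time of 48 h (on this read-out lower numbers stand for stronger inhibition and higher numbers for weaker inhibition), compound 1 `NS(=O)(=O)c1ccc(N/C(S)=N\c2ccnc3cc(C(F)(F)F)ccc23)cc1` gives 36600 nM, the lowest of the two numbers recorded here. Compound 2 `O=S(=O)(Nc1nccs1)c1ccc(N/C(S)=N\c2ccnc3cc(C(F)(F)F)ccc23)cc1` gives 95200 nM in this assay; putting a 1,3-thiazol-2-yl on the sulfonamide nitrogen produces a 2.6-fold higher number from compound 1 to compound 2 (0.42 log units; beyond the scatter). Compound 3 `O=S(=O)(Nc1ncccn1)c1ccc(N/C(S)=N\c2ccnc3cc(C(F)(F)F)ccc23)cc1` carries a pyrimidin-2-yl in the same place and in this assay was reported as "not active" (no number reported), so no number exists for it. Compound 4 `Cc1ccnc(NS(=O)(=O)c2ccc(N/C(S)=N\c3ccnc4cc(C(F)(F)F)ccc34)cc2)n1` is still unmeasured; it differs from compound 1 in that (4-methylpyrimidin-2-yl in place of hydrogen on a sulfonamide nitrogen). Going by the values given here, the one measured step that bears on this, a 2.6-fold higher number from compound 1 to compound 2 (0.42 log units; beyond the scatter), weakened inhibition modestly when a heteroaromatic ring was placed on that nitrogen, and compound 3, with a closely related ring there, gave no number at all. A step of similar or larger size toward weaker inhibition is therefore expected, a 3.3-fold higher number from compound 1 to compound 4 (0.52 log units; beyond the scatter), with a real chance that only a limit is returned. Compound 4 is expected to give about 120000 nM, within 50000 nM to 300000 nM.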

Compound 4, half-maximal inhibitory concentration: 31000 nM
Beside the measured number, compound 4's estimate is 3.9-fold (0.59 log units) above it; the whole stated range lies above it.
By their numbers in this assay, from the lowest: compounds 4 and 1 (each within the scatter of the next); then compound 2.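

In this assay the sulfonamide nitrogen can carry a six-membered ring with no loss that stands out from the scatter: 4-methylpyrimidin-2-yl in place of hydrogen gives a 1.2-fold lower number from compound 1 to compound 4 (0.07 log units; within the scatter) and so leaves the number level with that of the unsubstituted sulfonamide. The earlier step to a ring had pointed only toward weaker inhibition, but replacing the 1,3-thiazol-2-yl gives a 3.1-fold lower number from compound 2 to compound 4 (0.49 log units; beyond the scatter) and shows that the identity of the ring counts, not merely its presence; compound 3, whose ring lacks the methyl of compound 4, was reported as "not active". No measurement here explains these differences. On these data alone, it remains open whether an amine or a carboxylic acid on this ring, or a longer chain in place of the methyl, would preserve the activity. Also open, as far as these compounds go, is what changes elsewhere on the shared core would do.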